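This account rests on a few compounds, and the source may have more. Where it says the series, first, only, none or still open, it means among the compounds named here.

Of the compounds shown here, three sharing one core have been measured in a functional assay on DU-145 cells (Homo sapiens), read by sulforhodamine B assay, with a stated time of 5 days; a lower number here means a stronger inhibitor of growth, a higher number a weaker inhibitor of growth. Compound 1 `OC[C@H]1O[C@@H](n2cc(F)c3c(-c4ccco4)ncnc32)[C@H](O)[C@@H]1O` gives 5 nM, the lowest number of the three. Compound 3 `OC[C@H]1O[C@@H](n2cc(F)c3c(-c4ccsc4)ncnc32)[C@H](O)[C@@H]1O` gives 66 nM, and compound 2 `OC[C@H]1O[C@@H](n2cc(F)c3c(-c4c[nH]cn4)ncnc32)[C@H](O)[C@@H]1O` gives 890 nM. Compound 4 `OC[C@H]1O[C@@H](n2cc(Cl)c3c(-c4ccco4)ncnc32)[C@H](O)[C@@H]1O` is not yet measured. Its difference from compound 1 is chloro in place of fluoro on an aromatic carbon. The measured steps all exchange the furan-2-yl group or its replacements: thiophen-3-yl gives a 13-fold higher number from compound 1 to compound 3 (1.12 log units; beyond the scatter), 1H-imidazol-4-yl gives a 180-fold higher number from compound 1 to compound 2 (2.25 log units; beyond the scatter), and thiophen-3-yl in place of 1H-imidazol-4-yl gives a 13-fold lower number from compound 2 to compound 3 (1.13 log units; beyond the scatter). All three are large, but none exchanges the halogen, so they offer no direct measure of this change. Compound 4 keeps the furan-2-yl group, so only a small step in this assay is expected, perhaps towards a somewhat higher number. The expected step is a 1.6-fold higher number from compound 1 to compound 4 (0.20 log units; within the scatter). For compound 4 the estimated value is 8 nM, with an expected range from 2 nM to 35 nM.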

Compound 4, concentration for 50% growth inhibition: > 10000 nM
Compound 4 gave a limit, no number; the forecaster's own chance of this, stated with the estimate: 2%; middle value at least 1200-fold (3.09 log units) from the limit.
By their numbers in this assay, from the lowest: compound 1; then compound 3; then compound 2. At a limit, above all of these: compound 4.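

In this assay, chloro in place of fluoro on an aromatic carbon, with the furan-2-yl group kept, gives an at least 2000-fold higher number from compound 1 to compound 4 (3.30 log units; beyond the scatter). For the compounds shown here, this exchange of one halogen for another gives a larger step than the largest measured exchange at the other place, a 180-fold higher number from compound 1 to compound 2 (2.25 log units; beyond the scatter), so the earlier compounds, which all carry fluoro, gave no sign of how much this position on the five-membered aromatic ring can matter. The value of compound 4 is a limit of the assay, not a number: the limit of > 10000 nM in this assay, at which 1 of the 4 values shown sits.

With only fluoro and chloro shown at this position, it remains open whether hydrogen, methyl or bromo there would give a number close to that of compound 1. From the compounds shown here alone, it also remains open whether chloro would give a step of this size alongside thiophen-3-yl or 1H-imidazol-4-yl in place of furan-2-yl.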